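The compounds below may be only part of what the source reports. "The series", "measured", "known", "first", "only" and "open" are said of these compounds alone.

Measured so far in an assay (strain Wistar) for binding affinity to Neuronal acetylcholine receptor; alpha4/beta2 (Rattus norvegicus); on this read-out lower numbers stand for stronger inhibition and higher numbers for weaker inhibition:

- compound 1, `C=COc1cncc(N2CCNCC2)c1`: 190 nM
- compound 2, `COc1cc(N2CCNCC2)cnc1Br`: 180 nM
- compound 3, `Cc1ncc(N2CCNCC2)cc1Cl`: 520 nM

Compound 1 sits second highest among the three numbers. Its nearest neighbour is compound 2, whose value in this assay, 180 nM, lies within the scatter of the value of compound 1, so the two cannot be told apart. The furthest is compound 3, whose 520 nM stands beyond the scatter on the weaker side relative to compound 1. The three compounds differ at several places at once, so none of these gaps can be tied to a single structural change.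

The next compound, compound 4, `C#Cc1cncc(N2CCNCC2)c1`, is not yet measured. Against compound 1 the change is ethynyl in place of vinyloxy on an aromatic carbon. For the measured compounds named here, no measured pair shows this change or a related one, so there is no step to lean on. The two groups are of similar extent and both lack a hydrogen-bond donor; the vinyloxy group of compound 1 carries one acceptor that the ethynyl group does not. On this basis no step beyond the scatter is expected, with a slight lean toward a lower number.

For compound 4 the estimate in this assay is 140 nM, ranging from 45 nM to 450 nM, which amounts to an expected step of a 1.4-fold lower number from compound 1 to compound 4 (0.13 log units; within the scatter).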

Compound 4, half-maximal inhibitory concentration: 110 nM
Compound 4: middle estimate off by 1.3-fold (0.10 log units), on the high side; measured number inside the range.
By their numbers in this assay, from the lowest: compounds 4, 2 and 1 (each within the scatter of the next); then compound 3.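

For the compounds shown here, the first step that can be tied to one structural change comes from this assay, where ethynyl in place of vinyloxy on an aromatic carbon gives (a 1.7-fold lower number from compound 1 to compound 4 (0.24 log units; within the scatter)). The swap removes the oxygen, and with it the one hydrogen-bond acceptor counted on the leaving group, and it replaces a double bond outside the aromatic ring with a triple bond, yet the step stays within the scatter, so on this single pair neither the oxygen nor the double bond is needed to keep the number in this range. No measured data on the properties of the compounds or the two groups are available to explain the step.

From the compounds shown here alone, whether this place, two atoms from the ring nitrogen, would tolerate a different kind of group, such as an amine, a carboxylic acid or a longer alkyne chain, stays open, since one step within the scatter sets no limit on what fits there. Also open, going by these compounds, is whether the ethynyl-for-vinyloxy swap would behave the same way with further groups on the ring, as in compound 2 and compound 3, which differ from compound 4 in more than one place.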